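Moving a Single Fluorine on the Benzyl Group

The source may hold more compounds than are shown below. What is called first, only, known or untested is meant among the compounds shown, and "the series" means these compounds.

For the measured compounds named here, compound 1 `O=C(O)CN1C(=O)/C(=C/c2nc3ccccc3n2Cc2ccc(Br)cc2F)SC1=S` gives 21100 nM in a functional assay on PC-3 cells (Homo sapiens) for cytotoxicity, read by MTT assay, with a stated time of 48 h (on this read-out higher numbers stand for weaker inhibition and lower numbers for stronger inhibition), the second highest of the three numbers measured so far. Its nearest neighbour is compound 3 `O=C(O)CN1C(=O)/C(=C/c2nc3ccccc3n2Cc2ccc(F)cc2F)SC1=S`, which gives 21700 nM; the gap between them is within the scatter, so neither can be ranked above the other. The furthest is compound 2 `O=C(O)CN1C(=O)/C(=C/c2nc3ccccc3n2Cc2ccc(F)cc2)SC1=S`, which gives 4860 nM, reached by a 4.3-fold lower number from compound 1 to compound 2 (0.64 log units; beyond the scatter).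

Compound 4 `O=C(O)CN1C(=O)/C(=C/c2nc3ccccc3n2Cc2cccc(F)c2)SC1=S` differs from compound 1 by 3-fluorophenyl in place of 4-bromo-2-fluorophenyl on a saturated chain carbon bound to an aromatic nitrogen. Going by the values given here, two measured steps bear on this. Putting 4-fluorophenyl in place of 4-bromo-2-fluorophenyl gave a 4.3-fold lower number from compound 1 to compound 2 (0.64 log units; beyond the scatter), whereas fluoro in place of hydrogen gave a 4.5-fold higher number from compound 2 to compound 3 (0.65 log units; beyond the scatter). Among the compounds with values here, compound 4 carries one fluorine, as compound 2 does, but as 3-fluorophenyl, a ring that no measured pair covers. A lower number than compound 1 is therefore expected, though with less confidence than the step to compound 2 alone would suggest, and the expected step is a 3.0-fold lower number from compound 1 to compound 4 (0.48 log units; beyond the scatter). Compound 4 is estimated at 7000 nM, within a range from 2500 nM to 20000 nM.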

Compound 4, half-maximal inhibitory concentration: 35700 nM
Compound 4: the middle estimate sits 5.1-fold (0.71 log units) below what was measured; the measured number lies above the stated range.
By their numbers in this assay, from the lowest: compound 2; then compounds 1, 3 and 4 (each within the scatter of the next).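

Where the single fluorine sits matters in this assay: 3-fluorophenyl in place of 4-fluorophenyl gives a 7.3-fold higher number from compound 2 to compound 4 (0.87 log units; beyond the scatter), so carrying one fluorine, as compound 2 and compound 4 both do, does not by itself bring the lower number. The other two steps, a 1.7-fold higher number from compound 1 to compound 4 (0.23 log units; within the scatter) and a 1.6-fold higher number from compound 3 to compound 4 (0.22 log units; within the scatter), lie within the scatter, which leaves compound 2 as the only one of the four that stands apart, as the most potent. No measurement shown explains why the two single-fluorine rings differ.

As far as these compounds go, it remains open whether the result for compound 2 is particular to fluorine, or whether 4-chlorophenyl or 4-methoxyphenyl would behave alike. From the compounds shown here alone, how 2-fluorophenyl, plain phenyl or a longer chain between the ring and the aromatic nitrogen would compare is also open.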